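The compounds below may be only part of what the source reports. "The series", "measured", "known", "first", "only" and "open" are said of these compounds alone.

Working notes on the series.

Compound 1 `c1ccc(N2CCN(CCCCCOc3ccc4c(c3)CCC4)CC2)cc1` is the parent of the first pair. In a functional assay on the whole organism for inhibition, with Mus musculus as the target, at a dose of 25 mg/kg by the oral route (on this read-out higher numbers stand for more inhibition at the one dose given (going by the name of the read-out) and lower numbers for less inhibition), compound 1 gives 27%. Compound 2 `Fc1ccc(N2CCN(CCCCCOc3ccc4c(c3)CCC4)CC2)cc1` carries fluoro in place of hydrogen on an aromatic carbon, and in this assay compound 2 gives 58%; the step of a number 31 percentage points higher from compound 1 to compound 2 (beyond the scatter).

Compound 3 `O=[N+]([O-])c1cc2c(cc1OCCCN1CCN(c3ccccc3)CC1)CCC2` sits on a second core; the difference between the two cores is not broken down here. In this assay compound 3 gives 67%. Set against compound 2 the two values lie within the usual scatter, so no order is read between them. Set against compound 1 the two values show a gap beyond the scatter.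

Compound 4 `O=[N+]([O-])c1cc2c(cc1OCCCN1CCN(c3ccc(F)cc3)CC1)CCC2` is not yet measured. It differs from compound 3 by fluoro in place of hydrogen on an aromatic carbon, and the place reads word for word as for the step from compound 1 to compound 2; the same change occurs twice among the compounds shown. Set beside the measured a number 31 percentage points higher from compound 1 to compound 2 (beyond the scatter), the expected step for the second pair is a number 13 percentage points higher from compound 3 to compound 4 (beyond the scatter). It is expected smaller because compound 3 already gives 67%, a higher number in this assay than compound 1 starts from. Compound 4 is therefore estimated at 80%, with a likely range from 62% to 95%.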

Compound 4, a percentage reported as inhibition, in the whole organism at one dose (the size of the read-out at that dose, not a potency): 58%
The estimate for compound 4 lay 22 percentage points above the measured number; measured number outside the range, below it.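

On the core of compound 3, phenyl to 4-fluorophenyl gives a number 9 percentage points lower from compound 3 to compound 4 (within the scatter) in this assay, so no order is read between compound 3 and compound 4, and the large step seen on the core of compound 1 does not recur here. The effect of this change therefore does not carry from one core to the other in this series, and the two steps differ: the same change on two cores in this assay, a number 31 percentage points higher (beyond the scatter) from compound 1 to compound 2 and a number 9 percentage points lower (within the scatter) from compound 3 to compound 4, 40 percentage points apart, beyond the scatter of two such steps

This does not show what sets the two steps apart, since the core of compound 1 and the core of compound 3 are not broken down into single changes, and one pair on each core says nothing about how the fluoro change would behave on any further core.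

Still open, on these data alone, is whether chloro or methoxy in the same place on the phenyl ring would follow fluoro on either core. Also open, as far as these compounds go, is whether the step on the core of compound 3 would stay as it is with an amine or a nitrile in place of the nitro group, or with a longer chain to the piperazine.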